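A few compounds are considered here, and "the series" means these few. Any claim that something is new, unique, unknown or untested is made for them only; others in the source may bear on it.

Working notes on the series. Of the compounds shown here, two have been measured in a functional assay on HeLa cells (Homo sapiens) for inhibition, read by CCK-8 assay, with a stated time of 48 h; a higher number here means a weaker inhibitor, a lower number a stronger inhibitor. Compound 1, `O=S(=O)(NCCNC(=S)Nc1cccc(Cl)c1)c1ccc(-c2ccccc2OCc2ccccc2)s1`, gives 8400 nM in this assay. Compound 2, `COc1ccc(NC(=S)NCCNS(=O)(=O)c2sccc2-c2ccc(C)cc2Oc2ccc(O)c(O)c2)cc1`, returns only a limit in this assay, > 20000 nM, so no number is known for it; it sits at the limit of > 20000 nM in this assay, at which 1 of the 2 values shown sits. Compound 1 and compound 2 differ in more than one place, so nothing is drawn from that pair beyond their two values.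

The step under study runs from compound 2 to compound 3, `Cc1ccc(-c2ccsc2S(=O)(=O)NCCNC(=S)Nc2ccc([N+](=O)[O-])cc2)c(Oc2ccc(O)c(O)c2)c1`, which is not yet measured. The change is nitro in place of methoxy on an aromatic carbon. Among the measured compounds shown here, no measured step of this kind exists here, so the expectation rests on compound 2 alone, which shows only a limit of > 20000 nM. For compound 3 the step that the limit leaves unreadable from compound 2 to compound 3 is expected to lie within the scatter, with a fair chance that this assay again reports only a limit. Compound 3 is estimated at 25000 nM, between 7000 nM and 80000 nM.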

Compound 3, half-maximal inhibitory concentration: 6800 nM
Beside the measured number, compound 3's estimate is 3.7-fold (0.57 log units) above it; measured number below the stated range.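

In this assay, nitro in place of methoxy on this aromatic carbon, para to a large group, gives an at least 2.9-fold lower number from compound 2 to compound 3 (0.46 log units; beyond the scatter). Among the compounds shown here, this is the first readable step, and it shows that the group at this one place can bring the shared core of compound 2 from a limit to a measured number. The true size of the step stays unknown because the value for compound 2 is only a limit: the limit of > 20000 nM in this assay, at which 1 of the 3 values shown sits.

The compounds shown leave open whether nitro is particular in this respect, or whether another group at this place, such as an amine, a nitrile or a carboxylic acid, would give a similar number. Compound 1 differs from compound 3 in more than one place, so the effect of the other parts of the structure also remains unresolved.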